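The source may hold more compounds than are shown below. What is called first, only, known or untested is meant among the compounds shown, and "the series" means these compounds.

In a functional assay on HEL cells (Homo sapiens) for cytotoxicity (on this read-out higher numbers stand for lower toxicity in this test and lower numbers for higher toxicity in this test), three compounds built on one shared core have been examined. Compound 1, `CO[C@@H]1[C@@H](OC)[C@H](c2ccccc2)O[C@@H]2CO[C@@H](c3ccccc3)O[C@@H]12`, carries no result; its entry reads "not determined" (no result reported). Compound 2, `O=[N+]([O-])c1ccc([C@@H]2OC[C@H]3O[C@@H](c4ccccc4)[C@H](O)[C@@H](O)[C@@H]3O2)cc1`, gives 50 ug/mL. Compound 3, `O[C@@H]1[C@@H](O)[C@H](c2ccccc2)O[C@@H]2CO[C@@H](c3ccc(Cl)cc3)O[C@@H]12`, reaches only a limit of this assay, >= 100 ug/mL. For the measured compounds named here, the single measured step, an at least 2.0-fold higher number from compound 2 to compound 3 (0.30 log units; that floor lies within the scatter), rests on (the limit of >= 100 ug/mL in this assay, at which 1 of the 3 values shown sits), so its true size is not known. Compound 4, `O[C@@H]1[C@@H](O)[C@H](c2ccccc2)O[C@@H]2CO[C@@H](c3ccc(C(F)(F)F)cc3)O[C@@H]12`, differs from compound 3 by trifluoromethyl in place of chloro on an aromatic carbon. Going by the values given here, no measured step involves a trifluoromethyl group. Among the compounds with values here, the only guide is compound 3, whose value >= 100 ug/mL is a limit. Compound 4 is therefore expected to show a step of about a number no higher from compound 3 to compound 4 (the limit leaves the size open), nothing beyond the scatter. The estimate for compound 4 is 100 ug/mL, within a range from 50 ug/mL to 200 ug/mL.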

Compound 4, minimum cytotoxic concentration: 400 ug/mL
Beside the measured number, compound 4's estimate is 4.0-fold (0.60 log units) below it; the whole stated range lies below it.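

In this assay, swapping the group on this aromatic carbon now has a readable effect: trifluoromethyl in place of nitro gives an 8.0-fold higher number from compound 2 to compound 4 (0.90 log units; beyond the scatter). So a change at this position alone can separate two compounds by more than the scatter, with the trifluoromethyl compound the less toxic in this test. The step between compound 3 and compound 4 cannot be read, as compound 3 stands at a limit: the limit of >= 100 ug/mL in this assay, at which 1 of the 4 values shown sits.

On these data alone, whether chloro and trifluoromethyl truly differ here remains open. So does how an amine or a carboxylic acid at this position would behave.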